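Adding a Methoxy Group to Compound 3

A few compounds are considered here, and "the series" means these few. Any claim that something is new, unique, unknown or untested is made for them only; others in the source may bear on it.

Values in an ADME assay on MT4 cells (Homo sapiens) for cytotoxicity, read by MTT assay, with a stated time of 96 h; a lower number here means that less compound is tolerated, a higher number that more compound is tolerated:
- Compound 1 `COc1ccc(-c2nc3cc(C(C)O)ccc3[nH]2)c(OC)c1`: >= 100000 nM (a limit)
- Compound 2 `COc1ccc(-c2nc3cc(/C(C)=N/O)ccc3[nH]2)c(OC)c1`: >= 100000 nM (a limit)
- Compound 3 `COc1ccc(-c2nc3cc(/C(C)=N/NC(N)=S)ccc3[nH]2)cc1`: 5000 nM

Going by the values given here, compound 3 holds the only true number, 5000 nM. Compounds 1 and 2 sit at the limit of >= 100000 nM in this assay, at which 2 of the 3 values shown sit.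

Compound 4 `COc1ccc(-c2nc3cc(/C(C)=N/NC(N)=S)ccc3[nH]2)c(OC)c1` differs from compound 3 by one change: methoxy in place of hydrogen on an aromatic carbon. Among the compounds with values here, the only measured step, a step that the two limits leave unreadable from compound 1 to compound 2, concerns a different change and gives no size to carry over. With no measured guide, no shift beyond the usual scatter is expected in this assay, and no direction can be called. The expected result is a 1.2-fold higher number from compound 3 to compound 4 (0.08 log units; within the scatter). For compound 4 the estimated value is 6000 nM, with an expected range of 2000 nM to 25000 nM.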

Compound 4, half-maximal cytotoxic concentration: 72000 nM
Estimate against measurement, compound 4: 12-fold (1.08 log units) below, and the stated range ends below it.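

In this assay the added methoxy, ortho to a large group, gives a 14-fold higher number from compound 3 to compound 4 (1.16 log units; beyond the scatter) and so shows that this one position can carry a large shift while the rest of compound 3 stays unchanged. Both an at least 1.3-fold lower number from compound 2 to compound 4 (0.14 log units; that floor lies within the scatter) and an at least 1.3-fold lower number from compound 1 to compound 4 (0.14 log units; that floor lies within the scatter) are only floors, set by values that are limits and not numbers: the limit of >= 100000 nM in this assay, at which 2 of the 4 values shown sit.

From the compounds shown here alone, whether the shift belongs to methoxy itself stays open, and a hydroxy group, a fluorine atom or a longer chain such as ethoxy on this carbon would speak to that. Going by these compounds alone, also open is whether the shift holds with the side chain of compound 2 in place of the one in compound 3.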